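Chloro for fluoro on the benzyl ring: cytotoxicity readout

A few compounds are considered here, and "the series" means these few. Any claim that something is new, unique, unknown or untested is made for them only; others in the source may bear on it.

Measured compounds:
Compound 1, `Cc1c(Cc2ccc(F)cc2)c(=O)oc2cc(OCC(O)CN3CCC(C(N)=O)CC3)ccc12`, in an ADME assay on A549 cells (Homo sapiens) for cytotoxicity, read by CellTiter-Glo (on this read-out lower numbers stand for higher toxicity in this test and higher numbers for lower toxicity in this test), compound 1 gives 89300 nM.
Compound 2, `Cc1c(Cc2ccc(Cl)cc2)c(=O)oc2cc(OCC(O)CN3CCC(C(N)=O)CC3)ccc12`, in this assay compound 2 gives 40000 nM.
Compound 3, `Cc1c(Cc2ccc(-c3ccc(F)cc3)cc2)c(=O)oc2cc(OCC(O)CN3CCC(C(N)=O)CC3)ccc12`, in this assay compound 3 gives 19300 nM.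

Compound 1 and compound 2 differ by chloro in place of fluoro on an aromatic carbon. In this assay this gave a 2.2-fold lower number from compound 1 to compound 2 (0.35 log units; beyond the scatter). Compound 3 carries a different core than compound 1: the difference is 4-fluorophenyl in place of fluoro on an aromatic carbon, and the step was a 4.6-fold lower number from compound 1 to compound 3 (0.67 log units; beyond the scatter); against compound 2 it was a 2.1-fold lower number from compound 2 to compound 3 (0.32 log units; beyond the scatter).

Compound 4, `Cc1c(Cc2ccc(-c3ccc(Cl)cc3)cc2)c(=O)oc2cc(OCC(O)CN3CCC(C(N)=O)CC3)ccc12`, has not yet been measured. It differs from compound 3 by chloro in place of fluoro on an aromatic carbon, the same change that links compound 1 to compound 2, placed in the same surroundings.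

Because compound 1 to compound 2 gave a 2.2-fold lower number from compound 1 to compound 2 (0.35 log units; beyond the scatter), the step from compound 3 to compound 4 is expected to be about a 2.1-fold lower number from compound 3 to compound 4 (0.33 log units; beyond the scatter). Among the compounds with values here, only one earlier instance of the change supports this, so the range is kept wide. For compound 4 the estimated value in this assay is 9000 nM, between 3500 nM and 20000 nM.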

Compound 4, half-maximal cytotoxic concentration: 32900 nM
Compound 4: middle estimate off by 3.7-fold (0.56 log units), on the low side, outside the stated range (above it).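

In this assay, chloro for fluoro on the 4-fluorophenyl group gave a 1.7-fold higher number from compound 3 to compound 4 (0.23 log units; within the scatter), so the lower number seen with the same change on the core of compound 1 did not carry over, and the two instances differ: the same change on two cores in this assay, a 2.2-fold lower number (0.35 log units; beyond the scatter) from compound 1 to compound 2 and a 1.7-fold higher number (0.23 log units; within the scatter) from compound 3 to compound 4, 3.8-fold (0.58 log units) apart, beyond the scatter of two such steps

Replacing the smaller substituent with 4-chlorophenyl gave a 1.2-fold lower number from compound 2 to compound 4 (0.08 log units; within the scatter), which lies within the scatter, whereas the step with fluoro as the starting group gave a 2.7-fold lower number from compound 1 to compound 4 (0.43 log units; beyond the scatter), which lies beyond it.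

This shows that the step cannot be carried as a fixed amount between these two cores, but two instances give no rule for other cores and do not explain the difference.

The compounds shown leave open how a bromo or a methyl group in place of the chloro would read in this assay. They also leave open whether a carboxylic acid in place of the amide would alter how the change carries between cores.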